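The source may hold more compounds than are shown below. What is called first, only, known or untested is meant among the compounds shown, and "the series" means these compounds.

Compound 3 `Cc1nc(NC2CC2)nc(N[C@@H]2C[C@H](C(C)(C)O)[C@@H](O)[C@H]2O)c1-c1nc2c(C)nccc2s1` stands highest of the three in an ADME assay on the whole organism (plasma) for pharmacokinetics, with Rattus norvegicus as the target, with a stated time of 6 h, at a dose of 10 mg/kg by the oral route (a higher number here means more compound in the circulation at the dose given, a lower number less compound in the circulation), where compound 3 gives 27300 ng.h/mL. Compound 2 `CCC(O)(CC)[C@H]1C[C@@H](Nc2nc(NCCOC)nc(C)c2-c2nc3c(C)nccc3s2)[C@H](O)[C@@H]1O` gives 723 ng.h/mL and compound 1 `COCCNc1nc(C)c(-c2nc3cnccc3s2)c(N[C@@H]2C[C@H](C(C)(C)O)[C@@H](O)[C@H]2O)n1` gives 617 ng.h/mL in this assay; both gaps to compound 3 lie well beyond the scatter. Compound 4 `Cc1nc(NCC2CCCCO2)nc(N[C@@H]2C[C@H](C(C)(C)O)[C@@H](O)[C@H]2O)c1-c1nc2c(C)nccc2s1` differs from compound 3 in one place: (oxan-2-yl)methyl in place of cyclopropyl on a nitrogen on an aromatic ring. Within the data shown here, no measured pair shows this change, so the direction is unknown; compound 3 is the only one in the set with a high number, while compound 1 and compound 2 sit far lower. A drop beyond the scatter is expected, a 4.6-fold lower number from compound 3 to compound 4 (0.66 log units; beyond the scatter), tempered by the wide range seen across the set. Compound 4 is therefore estimated at 6000 ng.h/mL in this assay, with a range of 1500 ng.h/mL to 20000 ng.h/mL.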

Compound 4, area under the concentration-time curve: 5230 ng.h/mL
The estimate for compound 4 lay 1.1-fold (0.06 log units) above the measured number; measured number inside the range.
By their numbers in this assay, from the lowest: compounds 1 and 2 (each within the scatter of the next); then compound 4; then compound 3.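

The group on the nitrogen on an aromatic ring clearly affects the result in this assay: with the rest of the structure unchanged, (oxan-2-yl)methyl in place of cyclopropyl gives a 5.2-fold lower number from compound 3 to compound 4 (0.72 log units; beyond the scatter). Among these compounds, this is the first one-place comparison, and it shows that this position is not neutral for circulating compound. No measurement here accounts for the step. The compounds shown do not separate the effect of the ring oxygen from that of the larger group. A cyclohexylmethyl group or a tertiary amine on a short chain at this nitrogen would test that further.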